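This account rests on a few compounds, and the source may have more. Where it says the series, first, only, none or still open, it means among the compounds named here.

In a functional assay on the whole organism (strain Wistar) for inhibition, with Rattus norvegicus as the target, read by paw edema, with stated times of 60 min and 2 h, at a dose of 100 mg/kg by the oral route (on this read-out lower numbers stand for less inhibition and higher numbers for more inhibition at the one dose given (going by the name of the read-out)), compound 1 `CCNC(=O)CC1CCc2cc(OC)c(OC)cc21` gives 26%. Compound 2 `CCCNC(=O)CC1CCc2cc(OC)c(OC)cc21` gives 28% in this assay, and the step of a number 2 percentage points higher from compound 1 to compound 2 (within the scatter) leaves the two compounds together within the usual scatter; on the numbers shown, compound 2 stands alongside compound 1. Compound 3 `CCCCCNC(=O)CC1CCc2cc(OC)c(OC)cc21` differs from compound 2 by ethyl in place of hydrogen on a saturated chain carbon, three bonds along the chain from an amide-type nitrogen. For the measured compounds named here, the only measured step that bears on this is a number 2 percentage points higher from compound 1 to compound 2 (within the scatter), a chain lengthening that barely moved the read-out. A similar outcome is expected here, with a number 2 percentage points higher from compound 2 to compound 3 (within the scatter) in this assay and no step beyond the scatter. Compound 3 is estimated to give 30%, in a range from 15% to 45%.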

Compound 3, a percentage reported as inhibition, in the whole organism at one dose (the size of the read-out at that dose, not a potency): 34%
Compound 3: the middle estimate sits 4 percentage points below what was measured; low and high end bracket the measured number.
By their numbers in this assay, from the lowest: compounds 1, 2 and 3 (each within the scatter of the next).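

In this assay, putting ethyl on a saturated chain carbon, three bonds along the chain from an amide-type nitrogen, gives a number 6 percentage points higher from compound 2 to compound 3 (within the scatter). The larger change, propyl in place of hydrogen two bonds along the chain, gives a number 8 percentage points higher from compound 1 to compound 3 (within the scatter), so even the biggest chain difference here stays within the scatter and the three compounds cannot be ranked. Nothing available explains these numbers.

From the compounds shown here alone, it remains open whether a longer chain such as octyl would go beyond the scatter. The same question applies to a chain ending in an amine or a carboxylic acid.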